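The source may report more compounds than this note shows. Statements on the series, on what has been measured and on what is new or still open speak of the compounds shown alone.

Compound 3 `CCS(=O)(=O)Nc1cccc2c1CCCC2c1c[nH]cn1` is the strongest binder among the three compounds measured in an assay on isolated protein for binding affinity to Alpha-1A adrenergic receptor (Rattus norvegicus), read by radioligand binding (a higher number here means a weaker inhibitor, a lower number a stronger inhibitor), where compound 3 gives 46.8 nM. Its nearest neighbour is compound 2 `O=S(=O)(Nc1cccc2c1CCCC2c1c[nH]cn1)C1CC1`, which in this assay gives 537 nM; the step is an 11-fold lower number from compound 2 to compound 3 (1.06 log units; beyond the scatter). Furthest away is compound 1 `CCCS(=O)(=O)Nc1cccc2c1CCCC2c1c[nH]cn1`, which gives 1700 nM, a step of a 36-fold lower number from compound 1 to compound 3 (1.56 log units; beyond the scatter). Between the two weaker compounds the step is a 3.2-fold lower number from compound 1 to compound 2 (0.50 log units; beyond the scatter). All three of these steps turn on the group attached to the sulfonyl sulfur, while the five-membered aromatic ring with 2 nitrogen is the same in each.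

Compound 4 `CCS(=O)(=O)Nc1cccc2c1CCCC2c1c[nH]c(C)n1` departs from compound 3 in a different part of the molecule: methyl in place of hydrogen on an aromatic carbon. For the measured compounds named here, no measured step touches that ring, so none of the three steps bears directly on this change. The change adds a single carbon at a site well away from the sulfonyl group that governed the measured steps, and with nothing in the data to suggest a move in either direction, the expectation is a step of a 1.4-fold higher number from compound 3 to compound 4 (0.14 log units; within the scatter), that is, no change beyond the usual scatter. For compound 4 the estimate in this assay is 65 nM, with a range from 20 nM to 250 nM.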

Compound 4, inhibition constant: 794 nM
Compound 4: middle estimate off by 12-fold (1.09 log units), on the low side, outside the stated range (above it).
By their numbers in this assay, from the lowest: compound 3; then compounds 2 and 4 (each within the scatter of the next); then compound 1.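

For the compounds shown here, the change from 1H-imidazol-4-yl to 2-methyl-1H-imidazol-4-yl gives a 17-fold higher number from compound 3 to compound 4 (1.23 log units; beyond the scatter) in this assay, so the group on the sulfonyl sulfur is not the only part of compound 3 that moves this number: the aromatic carbon between two ring nitrogen atoms, which no earlier step touched, is just as telling. Set beside a 36-fold lower number from compound 1 to compound 3 (1.56 log units; beyond the scatter), where compound 1 carries one more methyl on the chain, the new step shows that a single added methyl raised the number from compound 3 at both sites where this was tried. The data shown give no reason for the new step and cannot say whether the methyl itself matters or any group on that carbon would do the same.

An ethyl, a chlorine or an amine on this ring carbon would show whether the number keeps rising with the group placed there. As far as these compounds go, it also remains open whether the same methyl has a step of similar size with the propyl of compound 1 or the cyclopropyl of compound 2 on the sulfonyl sulfur.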